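The source may hold more compounds than are shown below. What is called first, only, known or untested is meant among the compounds shown, and "the series" means these compounds.

Measured so far:
Compound 1 `O=C1C(=O)N(CC(CO)NCCCCNc2ccnc3cc(Cl)ccc23)c2ccccc21` gives 0%
Compound 2 `O=C1C(=O)N(CC(CO)NCCCNc2ccnc3cc(Cl)ccc23)c2ccccc21` gives 2%

Both compounds were tested in an ADME assay on HCT-116 cells (Homo sapiens) for cytotoxicity, read by MTT assay, with a stated time of 48 h, tested at 0.2 uM; on this read-out lower numbers stand for a weaker effect and higher numbers for a stronger effect at the one concentration tested. In this assay compound 1 gives 0%, and compound 2 gives 2%. On the two numbers shown, compound 2 stands at the top, but its nearest neighbour, compound 1, lies within the usual scatter of it, so the two cannot be told apart. Compound 3 `O=C1C(=O)N(CC(CO)NCCCNc2ccnc3cc(Cl)ccc23)c2ccc(Cl)cc21` has not yet been measured. It differs from compound 2 in one place: chloro in place of hydrogen on an aromatic carbon. Going by the values given here, nothing in the two numbers so far shows any movement beyond the scatter, so there is no basis for expecting a step of any size in either direction. The step from compound 2 to compound 3 is therefore estimated to be none beyond the scatter, a number 1 percentage points higher from compound 2 to compound 3 (within the scatter). In this assay compound 3 is expected to give about 3%, in a range from -6% to 14%.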

Compound 3, a percentage reported as inhibition, at one concentration (the size of the read-out at that concentration, not a potency): 0%
The estimate for compound 3 lay 3 percentage points above the measured number, within the range that was stated.
By their numbers in this assay, from the lowest: compounds 1, 3 and 2 (each within the scatter of the next).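

Going by these compounds alone, the earlier compounds differed in their chain, whereas compound 3 is the first to test a change on the six-membered aromatic ring of carbon only, part of a fused or bridged system of two rings. In this assay, chloro in place of hydrogen at this carbon, meta to a fused ring and para to a fused ring, gives a number 2 percentage points lower from compound 2 to compound 3 (within the scatter), so this single atom produces no readable change in the read-out. No available data offer an explanation for this result.

Compounds 2 and 3 alone leave open whether any other group on this carbon, such as an amine or a carboxylic acid, would give a different reading. They also leave open whether chloro would matter at another carbon of this ring.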